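Bis-thiazolidinedione biaryls: removing the phenol hydroxy

The compounds below may be only part of what the source reports. "The series", "measured", "known", "first", "only" and "open" are said of these compounds alone.

Measured compounds in an assay for inhibition of glutaminase kidney isoform, mitochondrial (Homo sapiens), read by coupled enzyme assay, with stated times of 10 min and 60 min; on this read-out higher numbers stand for weaker inhibition and lower numbers for stronger inhibition:
compound 1 `COc1cc(-n2c(C)cc(/C=C3\SC(=O)NC3=O)c2C)ccc1-c1ccc(/C=C2\SC(=O)NC2=O)cc1`: 355 nM
compound 2 `CCc1cc(-c2ccc(-n3c(-c4ccccc4)cc(/C=C4\SC(=O)NC4=O)c3-c3ccccc3)cc2)ccc1/C=C1\SC(=O)NC1=O`: 217 nM
compound 3 `Cc1cc(/C=C2\SC(=O)NC2=O)c(C)n1-c1ccc(-c2ccc(/C=C3\SC(=O)NC3=O)cc2)c(O)c1`: 760 nM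

Compound 3 gives the highest of the three numbers in this assay; compound 1 stands nearest to it and compound 2 furthest, both with lower values beyond the scatter. Going by the values given here, the only single-site step in the set is the one from compound 1 to compound 3, a 2.1-fold higher number from compound 1 to compound 3 (0.33 log units; beyond the scatter), where the oxygen substituent was trimmed from methyl to hydrogen.

Compound 4 `Cc1cc(/C=C2\SC(=O)NC2=O)c(C)n1-c1ccc(-c2ccc(/C=C3\SC(=O)NC3=O)cc2)cc1` carries the change (hydrogen in place of hydroxy on an aromatic carbon). This step bears on the same ring position as the step from compound 1 to compound 3, but it deletes the oxygen rather than altering what sits on it, so that step is only a partial guide. With the methoxy compound 1 and the unsubstituted compound 4 both lacking the phenol, a modest return toward the number of compound 1 is expected, though the direction is not secured by any measured pair. For compound 4 the expected step is a 1.7-fold lower number from compound 3 to compound 4 (0.23 log units; within the scatter), and the estimated value is 450 nM with a range of 200 nM to 1100 nM.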

Compound 4, half-maximal inhibitory concentration: 381 nM
Compound 4: the middle estimate sits 1.2-fold (0.07 log units) above what was measured, and the stated range covers the measured number.
By their numbers in this assay, from the lowest: compounds 2, 1, 4 and 3 (each within the scatter of the next, the first and the last beyond it).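

In this assay, removing the hydroxy gives a 2.0-fold lower number from compound 3 to compound 4 (0.30 log units; within the scatter) and removing the methoxy gives a 1.1-fold higher number from compound 1 to compound 4 (0.03 log units; within the scatter), so neither step separates compound 4 from the compound carrying oxygen at this aromatic carbon. The series therefore does not need an oxygen substituent here to keep its inhibition: compound 4, with only hydrogen on this carbon, cannot be told apart from compound 1. Going by these compounds alone, the gap between the methoxy and hydroxy compounds is the only one of these three steps beyond the scatter, and hydrogen does not separate from either group. No measurement shown gives a reason for these numbers. Going by these compounds, whether an amine, a carboxylic acid or a longer chain such as ethoxy on this carbon would move the number clear of hydrogen remains open. Also open, on these data alone, is whether the same tolerance holds on the core of compound 2.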